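This account rests on a few compounds, and the source may have more. Where it says the series, first, only, none or still open, it means among the compounds named here.

Compound 2 `C[C@H](CCCN1CCN(C)CC1)Nc1ccnc2cc(Cl)ccc12` gives 180000 nM in an assay for binding affinity, read by spectrophotometry (on this read-out higher numbers stand for weaker inhibition and lower numbers for stronger inhibition), the higher of the two numbers recorded; its nearest neighbour is compound 1 `C[C@@H](CCCN1CCN(C)CC1)Nc1ccnc2cc(Cl)ccc12`, which gives 140000 nM, and the two differ only in configuration as drawn (the fact that compounds 1 and 2 differ only in the configuration as drawn), the step of a 1.3-fold higher number from compound 1 to compound 2 (0.11 log units; within the scatter). Compound 3 `C[C@H](CCCNC(C)(C)C)Nc1ccnc2cc(Cl)ccc12` carries (tert-butyl)amino in place of 4-methylpiperazin-1-yl on a saturated chain carbon, four bonds along the chain from a nitrogen on an aromatic ring. Among the compounds with values here, the only measured step is the configuration change from compound 1 to compound 2, which says nothing about swapping the chain substituent, so no direction is expected for compound 3 beyond the scatter. Compound 3 is therefore estimated at 150000 nM, between 40000 nM and 600000 nM, the expected step being a 1.2-fold lower number from compound 2 to compound 3 (0.08 log units; within the scatter).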

Compound 3, half-maximal inhibitory concentration: 170000 nM
For compound 3 the middle estimate is 1.1-fold (0.05 log units) below the measured one; the measured number falls inside the stated range.
By their numbers in this assay, from the lowest: compounds 1, 3 and 2 (each within the scatter of the next).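

In this assay, (tert-butyl)amino in place of 4-methylpiperazin-1-yl on a saturated chain carbon gives a step within the scatter (a 1.1-fold lower number from compound 2 to compound 3 (0.02 log units; within the scatter)). The earlier compounds shown here spoke only to configuration, whereas this shows that the ring at this place can be exchanged for an open-chain amine with no measurable difference in the number. Nothing available bears on this exchange. Going by these compounds, whether a carboxylic acid or a primary amine at this place, or a longer chain, would give a number apart from these remains open. So does whether configuration matters with (tert-butyl)amino in place.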